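Difluorinated enone in place of the chlorobenzyloxy arm

The source may report more compounds than this note shows. Statements on the series, on what has been measured and on what is new or still open speak of the compounds shown alone.

Compound 1 `COC(=O)c1cc(-c2cccc(NC(=O)c3ccc(OCc4ccc(Cl)cc4)cc3)c2)on1` was examined in an ADME assay on Vero cells (Chlorocebus sabaeus) for cytotoxicity, read by MTT assay, with a stated time of 72 h; on this read-out lower numbers stand for higher toxicity in this test and higher numbers for lower toxicity in this test. In this assay compound 1 gives > 80 ug/mL, which is a limit of the assay and not a number. Compound 2 `COC(=O)c1cc(-c2cccc(NC(=O)c3ccc(/C=C/C(=O)c4ccc(F)cc4)cc3)c2)on1` in this assay gives > 20 ug/mL, again a limit. Compound 3 `CCCOc1ccc(C(=O)/C=C/c2ccc(C(=O)Nc3cccc(-c4cc(C(=O)OC)no4)c3)cc2)cc1` gives > 40 ug/mL in this assay, also a limit. So compound 1 stands only at a limit, as do the two other compounds: the limit of > 20 ug/mL in this assay, at which 1 of the 3 values shown sits, the limit of > 40 ug/mL in this assay, at which 1 of the 3 values shown sits, and the limit of > 80 ug/mL in this assay, at which 1 of the 3 values shown sits, describe the whole picture. Consequently the step that the two limits leave unreadable from compound 1 to compound 2 cannot be read, and neither can a step that the two limits leave unreadable from compound 2 to compound 3.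

Compound 4 `COC(=O)c1cc(-c2cccc(NC(=O)c3ccc(/C=C/C(=O)c4ccc(F)cc4F)cc3)c2)on1` differs from compound 1 by 2-((2,4-difluorophenyl)carbonyl)ethenyl in place of (4-chlorobenzyl)oxy on an aromatic carbon. The nearest measured step, a step that the two limits leave unreadable from compound 1 to compound 2, bears on this change but has no readable size, so no direction or size of step in this assay can be expected beyond the scatter. Compound 4 is therefore expected to give about 80 ug/mL in this assay, between 25 ug/mL and 250 ug/mL, most likely reported again as a limit. The expected step is a number no higher from compound 1 to compound 4 (the limit leaves the size open).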

Compound 4, half-maximal cytotoxic concentration: > 40 ug/mL
Compound 4 was reported as a limit; the forecaster's own chance of this, stated with the estimate: 80%; the middle value does not contradict the limit.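

Compound 1, compound 2, compound 3 and compound 4 all stand only at limits in this assay, so none of the steps linking compound 4 to the other three can be read. The compounds shown leave open where the half-maximal cytotoxic concentration of each actually lies, and whether any of these changes shifts it.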